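Methoxy-to-hydroxy step on an amide-bearing core

The source may hold more compounds than are shown below. What is called first, only, known or untested is meant among the compounds shown, and "the series" means these compounds.

Measured so far in a functional assay on A-431 cells (Homo sapiens) for antiproliferative activity, read by MTT assay, with a stated time of 72 h; a higher number here means a weaker inhibitor, a lower number a stronger inhibitor:
compound 1 `COc1cc(OC)c2c(=O)n(Cc3ccccc3)ccc2c1`, 3880 nM
compound 2 `COc1cc(O)c2c(=O)n(Cc3ccccc3)ccc2c1`, 8290 nM
compound 3 `C=CC(=O)Nc1c(OC)cc(OC)c2c(=O)n(-c3cccc(C(=O)N4CCCCC4)c3)ccc12`, 6230 nM

Compound 1 and compound 2 differ in one place: hydrogen in place of methyl on an oxygen on an aromatic ring. That step gives a 2.1-fold higher number from compound 1 to compound 2 (0.33 log units; beyond the scatter). Compound 3 carries a different core; how it differs from compound 1 is not broken down here. Its value in this assay lies within the scatter of both compound 2 and compound 1, so no order among the three is claimed.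

Compound 4 `C=CC(=O)Nc1c(OC)cc(O)c2c(=O)n(-c3cccc(C(=O)N4CCCCC4)c3)ccc12` is not yet measured. It differs from compound 3 in the same way: hydrogen in place of methyl on an oxygen on an aromatic ring. The place lines read the same word for word, so this is the same change, seen once in the measured pair and once here.

The expectation for compound 4 rests on a single earlier instance, compound 1 to compound 2, whose step is a 2.1-fold higher number from compound 1 to compound 2 (0.33 log units; beyond the scatter). Carrying that over, the step from compound 3 to compound 4 in this assay is estimated at a 2.1-fold higher number from compound 3 to compound 4 (0.32 log units; beyond the scatter). Compound 4 is therefore expected at about 13000 nM, with a range from 5500 nM to 32000 nM. Within the data shown here, the range is wide; only one prior step supports it.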

Compound 4, half-maximal inhibitory concentration: 5300 nM
Estimate against measurement, compound 4: 2.5-fold (0.39 log units) above, outside the stated range (below it).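

In this assay, methoxy to hydroxy on the core of compound 3 gives a 1.2-fold lower number from compound 3 to compound 4 (0.07 log units; within the scatter), so this pair shows no separation between the two values. Set beside the earlier pair on the core of compound 1, where the step lay beyond the scatter, the two steps cannot be told apart: the same change on two cores in this assay, a 2.1-fold higher number (0.33 log units; beyond the scatter) from compound 1 to compound 2 and a 1.2-fold lower number (0.07 log units; within the scatter) from compound 3 to compound 4, 2.5-fold (0.40 log units) apart, within the scatter of two such steps This shows neither that the change carries over from one core to the other with the same size nor that the core alters it; two pairs are too few to settle either reading, and they assign no cause.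

The compounds shown leave open how other groups at this place would read in this assay, for example an ethoxy group, a longer chain on the oxygen or an amine in place of the hydroxy. Among these compounds, also open is whether the step would hold on any further core, as only two cores carry this pair.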